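The compounds below may be only part of what the source reports. "The series", "measured", "known", "first", "only" and "open" are said of these compounds alone.

The measured compounds:

Compound 1, `CC(C)n1ncc2c(C(=O)NCc3cn(-c4ccc(F)cc4)nn3)cccc21`. In a functional assay on PC-3 cells (Homo sapiens) for inhibition, read by MTT assay, with a stated time of 72 h (a lower number here means a stronger inhibitor, a higher number a weaker inhibitor), compound 1 gives > 40000 nM, which is a limit of the assay rather than a number.

Compound 2, `Cc1ccccc1-n1cc(CNC(=O)c2cccc3c2cnn3C(C)C)nn1`. In this assay compound 2 gives 19200 nM.

Compound 2 therefore holds the only real number shown; the other value is a limit (the limit of > 40000 nM in this assay, at which 1 of the 2 values shown sits). For the measured compounds named here, the single measured step, an at least 2.0-fold lower number from compound 1 to compound 2 (0.31 log units; beyond the scatter), shows that exchanging the group on the aromatic nitrogen can shift the number at least modestly, but the full size of that shift is unknown, as compound 1 sits at a limit (the limit of > 40000 nM in this assay, at which 1 of the 2 values shown sits).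

Compound 3, `CC(C)n1ncc2c(C(=O)NCc3cn(-c4ccc(C(F)(F)F)cc4)nn3)cccc21`, has not yet been measured. It differs from compound 2 in one place: 4-(trifluoromethyl)phenyl in place of 2-methylphenyl on an aromatic nitrogen. The measured step concerns the same position but a different pair of groups, so it bears only loosely on this change and gives no clear direction. Compound 3 is expected to give about 20000 nM in this assay, with a range from 7000 nM to 60000 nM. This estimate means a step of a 1.0-fold higher number from compound 2 to compound 3 (0.02 log units; within the scatter), expected to lie within the scatter.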

Compound 3, half-maximal inhibitory concentration: 38600 nM
For compound 3 the middle estimate is 1.9-fold (0.29 log units) below the measured one, and the stated range covers the measured number.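

In this assay, placing 4-(trifluoromethyl)phenyl where 2-methylphenyl stood on the aromatic nitrogen gives a 2.0-fold higher number from compound 2 to compound 3 (0.30 log units; within the scatter), so these two groups cannot be told apart here, even though the entering group has more heavy atoms. Exchanging fluoro for trifluoromethyl on the aromatic carbon of the ring on that nitrogen gives an at least 1.0-fold lower number from compound 1 to compound 3 (0.01 log units; that floor lies within the scatter), and a floor of that size fixes no direction for the change. The value of compound 1, > 40000 nM, is a limit of the assay and not a number: the limit of > 40000 nM in this assay, at which 1 of the 3 values shown sits.

The compounds shown leave open whether something other than a substituted phenyl on the aromatic nitrogen, such as a benzyl group, a plain alkyl chain, or a phenyl carrying an amine or a carboxylic acid, would bring the number clearly down. They also leave open what happens when the shared core itself is changed, for example by putting a longer chain or a cyclopropyl group in place of its isopropyl group.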